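From Methyl to Propargyloxy on a Shared Core

This account rests on a few compounds, and the source may have more. Where it says the series, first, only, none or still open, it means among the compounds named here.

In a functional assay on aorta (Rattus norvegicus, strain Sprague-Dawley) for inhibition (a higher number here means that more compound is needed for the effect, a lower number that less compound is needed), compound 2 `Cc1cc2c(c3c1C[C@@H]1[C@@H](C)CO[C@]1(C)O3)C[C@@H]1[C@@H](C)CO[C@]1(C)O2` gives 40000 nM. Within the data shown here, the only other measured compound, compound 1 `CCCOc1cc2c(c3c1C[C@@H]1[C@@H](C)CO[C@]1(C)O3)C[C@@H]1[C@@H](C)CO[C@]1(C)O2`, gives 43000 nM, so compound 2 stands level with it, within the usual scatter. Compound 3 `C#CCOc1cc2c(c3c1C[C@@H]1[C@@H](C)CO[C@]1(C)O3)C[C@@H]1[C@@H](C)CO[C@]1(C)O2` keeps the shared core and alters one group: propargyloxy in place of methyl on an aromatic carbon. Put simply, propargyloxy takes the place of methyl on an aromatic carbon.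

Among the measured compounds shown here, one measured step bears on this change: a 1.1-fold lower number from compound 1 to compound 2 (0.03 log units; within the scatter), with methyl in place of propoxy on an aromatic carbon. That exchange left the number unchanged within the scatter, which suggests that this carbon may tolerate both a methyl and a longer group. Propoxy has no triple bond, however, and a single step is thin evidence, so the guide is only rough. No step beyond the scatter is therefore expected in this assay, in either direction.

The expected result is no change at the digits printed from compound 2 to compound 3 (within the scatter). For compound 3, the estimated value is 40000 nM, with an expected range from 15000 nM to 100000 nM.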

Compound 3, half-maximal effective concentration: 23000 nM
Beside the measured number, compound 3's estimate is 1.7-fold (0.24 log units) above it; the range from low to high includes it.
By their numbers in this assay, from the lowest: compounds 3, 2 and 1 (each within the scatter of the next).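

In this assay, swapping methyl for propargyloxy on this aromatic carbon gives a 1.7-fold lower number from compound 2 to compound 3 (0.24 log units; within the scatter) and so stays short of a real difference, even though the new group brings a triple bond and a hydrogen-bond acceptor that methyl lacks. The closer comparison is with the propoxy compound, since only the end of the chain differs: ethynyl in place of ethyl gives a 1.9-fold lower number from compound 1 to compound 3 (0.27 log units; within the scatter) and again does not go beyond the scatter, so a triple bond at the end of this chain shows no measurable effect of its own. Methyl, propoxy and propargyloxy thus now give numbers that each lie within the scatter of the next, which extends the earlier sign of tolerance at this carbon to a third group, but nothing available here explains why the numbers stay so close together.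

Still open, going by these compounds, is whether any group at this aromatic carbon can move the number beyond the scatter, for example an amine, a carboxylic acid or a much longer chain. A plain hydroxyl would also test whether the chain on the oxygen matters at all, since all three groups compared so far leave the number within the scatter.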